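Methyl on the hydroxy group of compound 1

A few compounds are considered here, and "the series" means these few. Any claim that something is new, unique, unknown or untested is made for them only; others in the source may bear on it.

Of the compounds shown here, two have been read so far in a physicochemical assay for solubility, using the shake flask method, in phosphate buffer, with a stated time of 90 min, at pH 6.8; on this read-out lower numbers stand for lower solubility and higher numbers for higher solubility. Compound 1 `O=C(/C=C(/C=C/c1ccc(O)cc1)NCCCO)/C=C/c1ccc(O)cc1` gives 137000 nM, the higher of the two numbers and beyond the scatter from compound 2 `COCCNC(=C\C(=O)/C=C/c1ccc(O)c(OC)c1)/C=C/c1ccc(O)c(OC)c1`, which gives 16700 nM. Compound 3 `COCCCNC(=C\C(=O)/C=C/c1ccc(O)cc1)/C=C/c1ccc(O)cc1` departs from compound 1 by a single change, hydroxy to methoxy, with methyl in place of hydrogen on an oxygen on a saturated carbon. Among the measured compounds shown here, no measured pair isolates this change, so the expectation is loose. For the measured compounds named here, the only other reading, compound 2 at 16700 nM, lies lower, though that compound differs from compound 1 in more than one place. A modest downward move in this assay is therefore expected, and the expected step is a 2.3-fold lower number from compound 1 to compound 3 (0.36 log units; beyond the scatter). Compound 3 is estimated at 60000 nM, with an expected range from 18000 nM to 140000 nM.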

Compound 3, solubility: 10500 nM
Estimate against measurement, compound 3: 5.7-fold (0.76 log units) above, outside the stated range (below it).
By their numbers in this assay, from the lowest: compounds 3 and 2 (each within the scatter of the next); then compound 1.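

In this assay, among the compounds shown here, the single change of hydroxy to methoxy, with methyl in place of hydrogen on an oxygen on a saturated carbon, gives a 13-fold lower number from compound 1 to compound 3 (1.12 log units; beyond the scatter). The earlier compounds shown here offered no pair that isolated this change; this pair shows that the read-out at this position is not indifferent to one added heavy atom, and that the step is large rather than modest. No measurement bearing on the origin of this step is at hand.

The compounds shown leave open whether an amine, a carboxylic acid or a longer chain at this place would read nearer compound 1 or nearer compound 3. They also leave open whether the same change gives a step of this size on any other compound.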